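Extending the aromatic cap of a hydroxamic acid series

The compounds below may be only part of what the source reports. "The series", "measured", "known", "first", "only" and "open" are said of these compounds alone.

Measured so far:
Compound 1, `O=C(CCCCCCCCC(=O)c1ccccc1)NO`: 135 nM
Compound 2, `O=C(CCCCCCCC(=O)c1ccc(C(F)(F)F)cc1)NO`: 45 nM
Compound 3, `O=C(CCCCCCCC(=O)c1ccc(Br)cc1)NO`: 45 nM

In an assay on isolated protein for inhibition of histone deacetylase 8 (Homo sapiens) (a higher number here means a weaker inhibitor, a lower number a stronger inhibitor), compound 3 gives 45 nM, level with compound 2 and lowest of the three numbers; compound 1 gives 135 nM, a higher number beyond the scatter. Among the compounds with values here, the only single-place step measured, no change at the digits printed from compound 2 to compound 3 (within the scatter), shows that swapping one small group on the aromatic ring for another leaves this assay unchanged. Compound 4, `O=C(CCCCCCCC(=O)c1ccc(-c2ccc(Br)cc2)cc1)NO`, is built by the change (4-bromophenyl in place of bromo on an aromatic carbon), which is larger than any step measured here, so it is only weakly foreshadowed. The most cautious expectation is a small step, a 1.3-fold higher number from compound 3 to compound 4 (0.12 log units; within the scatter), around the level of compound 3. Compound 4 is therefore estimated at 60 nM, between 20 nM and 200 nM.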

Compound 4, half-maximal inhibitory concentration: 2 nM
Beside the measured number, compound 4's estimate is 30-fold (1.48 log units) above it; measured number below the stated range.
By their numbers in this assay, from the lowest: compound 4; then compounds 2 and 3 (each within the scatter of the next); then compound 1.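

At this position on the aromatic ring, swapping one small group for another had left the number unchanged, but a whole second aromatic ring has a large effect. In this assay, 4-bromophenyl in place of bromo gives a far lower number (a 23-fold lower number from compound 3 to compound 4 (1.35 log units; beyond the scatter)), and 4-bromophenyl in place of trifluoromethyl does the same (a 23-fold lower number from compound 2 to compound 4 (1.35 log units; beyond the scatter)). The position therefore accepts a much larger group, with a stronger inhibitor as the result, but nothing available explains why. As far as these compounds go, it remains open how much of this gain depends on the bromo on the added ring, and whether a plain phenyl or a 4-aminophenyl would keep it.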